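Cyclooctyl in place of cyclohexyl on the amide

This account rests on a few compounds, and the source may have more. Where it says the series, first, only, none or still open, it means among the compounds named here.

Measured in a functional assay on BaF3 cells (Mus musculus) for antiproliferative activity, read by CCK-8 assay and cell counting, with a stated time of 76 h; on this read-out lower numbers stand for stronger inhibition and higher numbers for weaker inhibition:
- compound 1 `COc1cc2nccc(Oc3ccc(Nc4nn(C)cc4C(=O)NC45CCC(CC4)CC5)cc3)c2cc1C(N)=O`: > 10000 nM (a limit of the assay)
- compound 2 `COc1cc2nccc(Oc3ccc(Nc4nn(C)cc4C(=O)NC4CCCCC4)cc3)c2cc1C(N)=O`: 4800 nM

Within the data shown here, the only true number so far belongs to compound 2, at 4800 nM. For compound 1 the entry is a limit and not a number: the limit of > 10000 nM in this assay, at which 1 of the 2 values shown sits.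

Compound 3 `COc1cc2nccc(Oc3ccc(Nc4nn(C)cc4C(=O)NC4CCCCCCC4)cc3)c2cc1C(N)=O` keeps the rest of compound 2 and changes one group: cyclooctyl in place of cyclohexyl on an amide-type nitrogen. It carries cyclooctyl in place of cyclohexyl on an amide-type nitrogen.

Among the measured compounds shown here, one measured step bears on this: an at least 2.0-fold lower number from compound 1 to compound 2 (0.31 log units; beyond the scatter). There the smaller carbon group went with the lower number, but this is a single step. A modest move towards a higher number in this assay is therefore expected, and a result within the scatter would be no surprise. The expected change is a 1.5-fold higher number from compound 2 to compound 3 (0.16 log units; within the scatter). For compound 3 the estimated value is 7000 nM, with an expected range of 2500 nM to 15000 nM.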

Compound 3, half-maximal inhibitory concentration: 3210 nM
Compound 3: the middle estimate sits 2.2-fold (0.34 log units) above what was measured; the range from low to high includes it.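

In this assay, cyclohexyl and cyclooctyl on this amide-type nitrogen cannot be told apart: the step is a 1.5-fold lower number from compound 2 to compound 3 (0.17 log units; within the scatter). Counting carbon atoms alone therefore does not settle the matter, since the groups of compound 1 and compound 3 both hold 8 heavy atoms, one as 2 six-membered rings and the other as a single eight-membered ring, and the step is an at least 3.1-fold lower number from compound 1 to compound 3 (0.49 log units; beyond the scatter). The entry for compound 1 is a limit and not a number: the limit of > 10000 nM in this assay, at which 1 of the 3 values shown sits.

Still open, as far as these compounds go, is whether a smaller ring such as cyclopropyl, or an open chain such as n-octyl, would move the number beyond the scatter. A ring holding a nitrogen atom, such as piperidine, also remains untested among the compounds shown here.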